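Nitro to Cyano on the Benzyl Group

The source may report more compounds than this note shows. Statements on the series, on what has been measured and on what is new or still open speak of the compounds shown alone.

compound 1 `Cc1ccc(Cn2cc(CO/N=C/c3c(-c4ccc(F)cc4)nc4ccc(Br)cn34)nn2)cc1`: 100 mg/kg
compound 2 `O=[N+]([O-])c1ccc(Cn2cc(CO/N=C/c3c(-c4ccc(F)cc4)nc4ccc(Br)cn34)nn2)cc1`: 100 mg/kg

In a functional assay on the whole organism (strain NMRI) with Mus musculus as the target, with a stated time of 4 h (a higher number here means that more compound is needed for the effect, a lower number that less compound is needed), compound 1 gives 100 mg/kg and compound 2 gives 100 mg/kg. For the measured compounds named here, the one measured step, no change at the digits printed from compound 1 to compound 2 (within the scatter), shows that exchanging the group on this aromatic carbon left the dose where it was, so compound 2 stands level with compound 1. Compound 3 `N#Cc1ccc(Cn2cc(CO/N=C/c3c(-c4ccc(F)cc4)nc4ccc(Br)cn34)nn2)cc1` carries the change cyano in place of nitro on an aromatic carbon at the same position. Going by the values given here, since the only step that bears on this position was flat, the expected step in this assay is none beyond the scatter, no change at the digits printed from compound 2 to compound 3 (within the scatter). Compound 3 is therefore estimated at 100 mg/kg, in the range 50 mg/kg to 200 mg/kg.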

Compound 3, minimum effective dose: 100 mg/kg
Compound 3: middle estimate and measured number agree at the digits printed; the measured number falls inside the stated range.
By their numbers in this assay, from the lowest: compounds 1, 2 and 3 (each within the scatter of the next).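

In this assay, cyano in place of nitro on the aromatic carbon para to a large group gives no change at the digits printed from compound 2 to compound 3 (within the scatter) and cyano in place of methyl gives no change at the digits printed from compound 1 to compound 3 (within the scatter) as the second reading at this position. Methyl, nitro and cyano on the benzyl group are thus three groups within the scatter of one another, where the earlier pair offered only two. Nothing available explains this flat result. The compounds shown leave open whether an amine, a carboxylic acid or a longer chain at this place would shift the minimum effective dose.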